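This account rests on a few compounds, and the source may have more. Where it says the series, first, only, none or still open, it means among the compounds named here.

In an ADME assay on HeLa cells (Homo sapiens) for cytotoxicity (on this read-out lower numbers stand for higher toxicity in this test and higher numbers for lower toxicity in this test), compound 2, `CCN(CC)CN1C(=O)/C(=N/NC(=S)Nc2ccc(Cl)cc2)c2ccccc21`, gives >= 4000 nM, which is a limit of the assay rather than a number. Compound 1, `CCN(CC)CN1C(=O)/C(=N/NC(=S)Nc2ccccc2)c2cc(Cl)ccc21`, gives >= 20000 nM in this assay, again a limit. Compound 3, `CCN(CC)CN1C(=O)/C(=N/NC(=S)Nc2ccc(C)cc2)c2cc(Cl)ccc21`, gives >= 4000 nM in this assay, also a limit. For the measured compounds named here, the only step between measured compounds differing in one place, a step that the two limits leave unreadable from compound 1 to compound 3, therefore cannot be read in size. Compound 4, `CCN(CC)CN1C(=O)/C(=N/NC(N)=S)c2ccccc21`, differs from compound 2 by hydrogen in place of 4-chlorophenyl on an amide-type nitrogen. No measured step bears on this change, and every shown value sits at a limit, as the limit of >= 20000 nM in this assay, at which 1 of the 3 values shown sits, and the limit of >= 4000 nM in this assay, at which 2 of the 3 values shown sit, show. The expected step that the limit leaves unreadable from compound 2 to compound 4 is judged to lie within the scatter. Compound 4 is estimated at 10000 nM, ranging from 3000 nM to 40000 nM.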

Compound 4, minimum cytotoxic concentration: > 100000 nM
Compound 4: no number, only a limit; the forecaster's own chance of this, stated with the estimate: 75%; middle value at least 10-fold (1.00 log units) away from the limit.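

Compound 2 and compound 4 both stand at limits in this assay, so the step between them cannot be read. The compounds shown leave open how far, if at all, hydrogen in place of 4-chlorophenyl shifts this read-out.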